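The source may hold more compounds than are shown below. What is called first, only, known or untested is meant among the compounds shown, and "the series" means these compounds.

Measured in a functional assay on MOLT-4F cells (Homo sapiens) for antiproliferative activity; a lower number here means a stronger inhibitor of growth, a higher number a weaker inhibitor of growth:
compound 1 `COCCCCCCCCCCCCCCC/C=C1\CC(CO)(COC(=O)C(C)(C)C)OC1=O`: 0.498 ug/mL
compound 2 `COCCCCCCCCCCC/C=C1\CC(CO)(COC(=O)C(C)(C)C)OC1=O`: 2.38 ug/mL
compound 3 `CC(C)(C)C(=O)OCC1(CO)C/C(=C\CCCCCCCCCCCO)C(=O)O1`: 1.34 ug/mL

In this assay compound 3 gives 1.34 ug/mL. It cannot be told apart from its methyl ether, as the step is a 1.8-fold lower number from compound 2 to compound 3 (0.25 log units; within the scatter). Against the remaining compound it does separate, with a 2.7-fold higher number from compound 1 to compound 3 (0.43 log units; beyond the scatter).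

The next compound is compound 4 `CC(=O)NCCCCCCCCCCCCCCC/C=C1\CC(CO)(COC(=O)C(C)(C)C)OC1=O`. The change is 4-acetamidobutyl in place of hydroxy on a saturated chain carbon, ten or more bonds along the chain from a double-bonded chain carbon.

Within the data shown here, two measured steps bear on this place. Compound 1 carries 4-methoxybutyl there, and replacing that group with hydroxy gave a 2.7-fold higher number from compound 1 to compound 3 (0.43 log units; beyond the scatter). Replacing it with methoxy gave a 4.8-fold higher number from compound 1 to compound 2 (0.68 log units; beyond the scatter). Both steps are modest, and both run towards a weaker inhibitor of growth when the butyl extension is lost. Compound 4 regains a butyl extension, so a modest move towards a lower number is expected. Among the measured compounds shown here, none of the measured compounds carries 4-acetamidobutyl, however, so the size remains uncertain and the range must stay wide.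

The expected step is a 1.8-fold lower number from compound 3 to compound 4 (0.25 log units; within the scatter). For compound 4 the estimate is 0.75 ug/mL, with an expected range of 0.25 ug/mL to 2.2 ug/mL.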

Compound 4, concentration for 50% growth inhibition: 6.35 ug/mL
Compound 4: middle estimate off by 8.5-fold (0.93 log units), on the low side, outside the stated range (above it).
By their numbers in this assay, from the lowest: compound 1; then compounds 3 and 2 (each within the scatter of the next); then compound 4.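

In this assay, restoring the length of the chain does not by itself restore the lower number: with the chain length of compound 1 kept and only the end group changed, acetamido in place of methoxy gives a large step, a 13-fold higher number from compound 1 to compound 4 (1.11 log units; beyond the scatter). Compound 4 also separates from the two shorter compounds, with a 4.7-fold higher number from compound 3 to compound 4 (0.68 log units; beyond the scatter) and a 2.7-fold higher number from compound 2 to compound 4 (0.43 log units; beyond the scatter), which makes it the weakest inhibitor of growth of the four. The lower number seen with 4-methoxybutyl therefore belongs to that group and not to any extension at this place, so the end group matters here as well as the reach of the chain. Nothing available explains why the acetamido end stands so far from the methoxy end. Still open, going by these compounds, is how a hydroxy, an amine or a carboxylic acid would fare at the end of the chain of compound 1, and whether a longer chain ending in methoxy would go lower still or turn back up.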